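The source may report more compounds than this note shows. Statements on the series, on what has been measured and on what is new or still open speak of the compounds shown alone.

Measured in a functional assay on SK-OV-3 cells (Homo sapiens) for cytotoxicity; on this read-out lower numbers stand for stronger inhibition of growth and higher numbers for weaker inhibition of growth:
- compound 1 `COc1ccc(C2=C(c3ccc(SC)cc3)CC3CCCN3C2=O)cc1C`: 15000 nM
- compound 2 `CSc1ccc(C2=C(c3ccc(F)c(C)c3)C(=O)N3CCCC3C2)cc1`: 300 nM
- compound 3 `CSc1ccc(C2=C(c3ccc(O)cc3)C(=O)N3CCCC3C2)cc1`: > 100000 nM

Compound 3 gives no number in this assay, only the limit > 100000 nM. For the measured compounds named here, it is the only one of the three compounds that stops at a limit.

Compound 4 `CSc1ccc(C2=C(c3ccc(Br)cc3)C(=O)N3CCCC3C2)cc1` has bromo in place of hydroxy on an aromatic carbon, para to a large group, so 4-hydroxyphenyl becomes 4-bromophenyl: bromo in place of hydroxy on an aromatic carbon.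

Two measured steps replace the 4-hydroxyphenyl group of compound 3 with a different aryl group, and both are seen from the other side. One is an at least 6.6-fold higher number from compound 1 to compound 3 (0.82 log units; beyond the scatter), which is at least modest. The other is an at least 330-fold higher number from compound 2 to compound 3 (2.52 log units; beyond the scatter), which is large. A third step, a 50-fold lower number from compound 1 to compound 2 (1.70 log units; beyond the scatter), is also large and shows a halogen giving the lower number in place of an oxygen-linked group. Going by the values given here, compounds 1 and 2 also carry a methyl group that compound 4 lacks, and no measured compound has 4-bromophenyl, so these steps guide the estimate only loosely.

A large step towards lower numbers is therefore expected, and the estimated change is an at least 100-fold lower number from compound 3 to compound 4 (2.00 log units; beyond the scatter). For compound 4 the expected value is 1000 nM, within an estimated range of 200 nM to 8000 nM.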

Compound 4, concentration for 50% growth inhibition: 9000 nM
Compound 4: middle estimate off by 9.0-fold (0.95 log units), on the low side; measured number above the stated range.
By their numbers in this assay, from the lowest: compound 2; then compounds 4 and 1 (each within the scatter of the next). At a limit, above all of these: compound 3.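

In this assay, bromo in place of hydroxy on this aromatic carbon, para to a large group, gives an at least 11-fold lower number from compound 3 to compound 4 (1.04 log units; beyond the scatter), so this single change is enough to turn a compound without a measured number into one with a number, and it does so on an aryl group that carries no methyl. Compound 3 gives only a limit, which leaves that step without an upper end: the limit of > 100000 nM in this assay, at which 1 of the 4 values shown sits. The bromo compound still falls short of the best aryl group shown, with a 30-fold higher number from compound 2 to compound 4 (1.48 log units; beyond the scatter), while the comparison with the methoxy compound gives a 1.7-fold lower number from compound 1 to compound 4 (0.22 log units; within the scatter), so 4-bromophenyl and 4-methoxy-3-methylphenyl cannot be told apart in this assay.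

The step from compound 2 changes the halogen and the methyl group together, so the compounds shown do not tell how much of it belongs to fluoro and how much to methyl. As far as these compounds go, it also remains open how a chloro group, an amine or a carboxylic acid would fare in place of bromo on this same aromatic carbon.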